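Ethylamino replaces isobutyl on the carbonyl of compound 3

The source may report more compounds than this note shows. Statements on the series, on what has been measured and on what is new or still open speak of the compounds shown alone.

The series shares one core, shown for compound 1 `CC1=C(C(=O)OC(C)(C)C)C(c2ccoc2)NC(=O)N1`, compound 2 `CC(=O)C1=C(C)NC(=O)NC1c1ccoc1` and compound 3 `CC1=C(C(=O)CC(C)C)C(c2ccoc2)NC(=O)N1`. In an assay on membranes from CHO cells for displacement of a labelled ligand from adenosine receptor A1 (Homo sapiens), read by scintillation counting, with a stated time of 60 min, tested at 1 uM (on this read-out higher numbers stand for more inhibition at the one concentration tested (going by the name of the read-out) and lower numbers for less inhibition), compound 1 gives 11%, compound 2 gives 6% and compound 3 gives 23%, the highest of the three numbers, with both steps to it beyond the scatter.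

Compound 4 `CCNC(=O)C1=C(C)NC(=O)NC1c1ccoc1` is not yet measured. It differs from compound 3 in one place: ethylamino in place of isobutyl on a carbonyl carbon.

Among the compounds with values here, two measured steps bear on the carbonyl substituent. The step of a number 12 percentage points higher from compound 1 to compound 3 (beyond the scatter) replaced tert-butoxy by isobutyl, and the step of a number 17 percentage points higher from compound 2 to compound 3 (beyond the scatter) put isopropyl in place of hydrogen on the saturated chain carbon bound to the carbonyl carbon. Both point in the same direction: the larger isobutyl group on the carbonyl carbon went with the highest number, and the smaller groups in compound 1 and compound 2 did not. Ethylamino is smaller than isobutyl and brings a hydrogen-bond donor that none of the measured groups carried, so there is no direct precedent; the expectation is therefore a modest downward step, a number 13 percentage points lower from compound 3 to compound 4 (beyond the scatter), toward the numbers of compound 1 and compound 2.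

Compound 4 is thus estimated to give 10% in this assay, within a range from 0% to 22%.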

Compound 4, a percentage reported as inhibition, at one concentration (the size of the read-out at that concentration, not a potency): 1%
Compound 4: the middle estimate sits 9 percentage points above what was measured, within the range that was stated.
By their numbers in this assay, from the lowest: compounds 4, 2 and 1 (each within the scatter of the next); then compound 3.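

In this assay, within the data shown here, ethylamino on the carbonyl carbon gives a number 22 percentage points lower from compound 3 to compound 4 (beyond the scatter) and so does not hold the number reached with isobutyl, even though ethylamino is the only nitrogen-linked group of the four and the only one with a hydrogen-bond donor. Set against the other groups, the change gives a number 5 percentage points lower from compound 2 to compound 4 (within the scatter) and a number 10 percentage points lower from compound 1 to compound 4 (within the scatter) so that, at this position, ethylamino cannot be told apart from methyl or tert-butoxy, and compound 3 alone stands apart from the other three compounds. Nothing measured here accounts for the difference between isobutyl and ethylamino.

Ethylamino differs from isobutyl both in its nitrogen and in its carbon count, and the compounds shown do not separate the two: a propyl group on the same carbonyl carbon would keep a carbon in place of the nitrogen, while a dimethylamino group would keep the nitrogen without the amide hydrogen. Going by these compounds, whether a chain longer than isobutyl would give a higher number in this assay also remains open.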